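This account rests on a few compounds, and the source may have more. Where it says the series, first, only, none or still open, it means among the compounds named here.

Working notes on the series. For the measured compounds named here, in a functional assay on SMMC-7721 cells (Homo sapiens) for antiproliferative activity, read by MTT assay, with a stated time of 48 h (on this read-out higher numbers stand for weaker inhibition and lower numbers for stronger inhibition), compound 3 `Cn1cc(C2=C(c3nn(CCCCn4ccnc4)c4ncccc34)C(=O)NC2=O)c2ccccc21` gives 29200 nM, the only true number so far. Compound 1 `CN1CCN(CCCn2nc(C3=C(c4cn(C)c5ccccc45)C(=O)NC3=O)c3cccnc32)CC1` stands at a limit of this assay, > 100000 nM. Compound 2 `Cn1cc(C2=C(c3n[nH]c4ncccc34)C(=O)NC2=O)c2ccccc21` stands at that same limit, > 100000 nM.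

Compound 4 `Cn1cc(C2=C(c3nn(CCn4ccnc4)c4ncccc34)C(=O)NC2=O)c2ccccc21` carries this change against compound 3: 1H-imidazol-1-yl in place of 2-(1H-imidazol-1-yl)ethyl on a saturated chain carbon, two bonds along the chain from an aromatic nitrogen. Put differently, 4-(1H-imidazol-1-yl)butyl gives way to 2-(1H-imidazol-1-yl)ethyl.

Going by the values given here, two measured steps bear on it, though neither varies the chain length: an at least 3.4-fold lower number from compound 2 to compound 3 (0.53 log units; beyond the scatter), on introducing the 4-(1H-imidazol-1-yl)butyl group, and an at least 3.4-fold lower number from compound 1 to compound 3 (0.53 log units; beyond the scatter), on exchanging the chain end. Both start from a limit, so each gives only a minimum size. Among the compounds with values here, they tie the one measurable value to the 4-(1H-imidazol-1-yl)butyl group of compound 3, so a lean towards a higher number is reasonable, but no step clearly beyond the scatter can be claimed. The expected change is a 1.7-fold higher number from compound 3 to compound 4 (0.23 log units; within the scatter). Compound 4 is expected at 50000 nM, with an estimated range of 15000 nM to 100000 nM.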

Compound 4, half-maximal inhibitory concentration: > 100000 nM
Compound 4: a limit, no number; the forecaster's own chance of this, stated with the estimate: 35%; middle value at least 2.0-fold (0.30 log units) away from the limit.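

Replacing 4-(1H-imidazol-1-yl)butyl with 2-(1H-imidazol-1-yl)ethyl on the aromatic nitrogen gives an at least 3.4-fold higher number from compound 3 to compound 4 (0.53 log units; beyond the scatter) in this assay, and this size is only a minimum, as compound 4 stands at a limit of the assay. For the compounds shown here, the imidazole ring is kept in this change, so in this pair the ring alone does not give a measurable value, and the one true number depends on the longer chain of compound 3. The steps from compound 1 and from compound 2 to compound 4 cannot be read, because both ends of each are limits: the limit of > 100000 nM in this assay, at which 3 of the 4 values shown sit.

Open, going by these compounds, is how 3-(1H-imidazol-1-yl)propyl or a chain longer than butyl would read at this position. Also open, on these data alone, is whether another chain end on the butyl chain, such as a primary amine or a carboxylic acid, would match the imidazole.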